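Hydroxy for Fluoro on the Anilino Ring

The source may hold more compounds than are shown below. What is called first, only, known or untested is meant among the compounds shown, and "the series" means these compounds.

Compound 1, `O=C(/C=C\Nc1ccc(O)cc1)c1cn(-c2ccccc2)nc1-c1ccc(Cl)cc1`: 1910 nM
Compound 2, `COc1ccc(-c2nn(-c3ccccc3)cc2C(=O)/C=C\Nc2ccc(F)cc2)cc1`: 3980 nM

In a functional assay on A549 cells (Homo sapiens) for antiproliferative activity, read by MTT assay, with a stated time of 48 h (a lower number here means a stronger inhibitor, a higher number a weaker inhibitor), compound 2 stands at the higher of the two numbers, with compound 1 lower by a gap beyond the scatter. Compound 3, `COc1ccc(-c2nn(-c3ccccc3)cc2C(=O)/C=C\Nc2ccc(O)cc2)cc1`, has not yet been measured. It differs from compound 2 by hydroxy in place of fluoro on an aromatic carbon. Compounds 1 and 2 differ in two places, so their values alone cannot isolate this change. A modest step toward a lower number is expected, a 1.6-fold lower number from compound 2 to compound 3 (0.20 log units; within the scatter). Compound 3 is expected to give 2500 nM, in the range 1000 nM to 6500 nM.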

Compound 3, half-maximal inhibitory concentration: 2770 nM
Compound 3: the middle estimate sits 1.1-fold (0.04 log units) below what was measured; low and high end bracket the measured number.
By their numbers in this assay, from the lowest: compounds 1, 3 and 2 (each within the scatter of the next, the first and the last beyond it).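

In this assay the exchange of 4-fluorophenyl for 4-hydroxyphenyl on the amino group gives a 1.4-fold lower number from compound 2 to compound 3 (0.16 log units; within the scatter) and so shows that this position accepts either group without a step beyond the scatter. With the hydroxy group held fixed, methoxy in place of chloro on an aromatic carbon gives a 1.5-fold higher number from compound 1 to compound 3 (0.16 log units; within the scatter) and so neither single change here reaches beyond the scatter. No evidence is available to explain the size of these steps. As far as these compounds go, whether an amine, a carboxylic acid or a longer chain at this position would give a step beyond the scatter remains open.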